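The source may hold more compounds than are shown below. What is called first, only, known or untested is meant among the compounds shown, and "the series" means these compounds.

Measured in a functional assay on A549 cells (Homo sapiens) for antiproliferative activity, read by MTT assay, with a stated time of 48 h; on this read-out lower numbers stand for stronger inhibition and higher numbers for weaker inhibition:
- compound 1 `Cc1ccc(/C=C/C(=O)Nc2nnc(-c3ccccc3)s2)cc1`: 1.58 ug/mL
- compound 2 `O=C(/C=C/c1ccccc1)Nc1nnc(-c2ccc(Br)cc2)s1`: 2.18 ug/mL

Only these two numbers are available. Compound 2 at 2.18 ug/mL lies within the usual scatter of compound 1, so the two cannot be told apart. The next compound, compound 3 `Cc1ccc(/C=C/C(=O)Nc2nnc(-c3ccc(Br)cc3)s2)cc1`, is compound 2 with methyl in place of hydrogen on an aromatic carbon, turning phenyl into 4-methylphenyl: methyl in place of hydrogen on an aromatic carbon. Compound 1 already carries this 4-methylphenyl group and gives 1.58 ug/mL. For the measured compounds named here, no measured pair isolates this change, so the expectation is weakly supported. In this assay, no step beyond the scatter is expected, in either direction. The estimated change is a 1.2-fold lower number from compound 2 to compound 3 (0.08 log units; within the scatter). For compound 3, the expected value is 1.8 ug/mL, with an estimated range from 0.7 ug/mL to 4.5 ug/mL.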

Compound 3, half-maximal inhibitory concentration: 1.51 ug/mL
The estimate for compound 3 lay 1.2-fold (0.08 log units) above the measured number, and the stated range covers the measured number.
By their numbers in this assay, from the lowest: compounds 3, 1 and 2 (each within the scatter of the next).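

In this assay, methyl on the aromatic carbon turns phenyl into 4-methylphenyl while the bromo group stays in place, and this gives a 1.4-fold lower number from compound 2 to compound 3 (0.16 log units; within the scatter) with nothing else altered. For the compounds shown here, the second single change, which puts a bromo group where hydrogen stood with the 4-methylphenyl group kept, gives a 1.0-fold lower number from compound 1 to compound 3 (0.02 log units; within the scatter) and so also yields no step that can be told from the scatter. No further measurement is available to explain these results.

Going by these compounds, whether an amine or a carboxylic acid in place of the methyl would give a step beyond the scatter remains open. Also open, on these data alone, is how a compound with hydrogen in both of these places would compare with compound 1, compound 2 and compound 3.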